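Amide nitrogen variation on the propanamide chain

This account rests on a few compounds, and the source may have more. Where it says the series, first, only, none or still open, it means among the compounds named here.

Compound 1 `O=C(O)/C=C/c1ccc(NCc2cccc(Oc3ccccc3)c2)cc1`, compound 2 `CC(CC(=O)O)c1ccc(NCc2cccc(Oc3ccccc3)c2)cc1` and compound 3 `CNC(=O)CCc1ccc(NCc2cccc(Oc3ccccc3)c2)cc1` share one core and differ only in the chain on the aromatic carbon. In a functional assay on CHO cells for agonist activity at Free fatty acid receptor 1 (Homo sapiens) (a higher number here means that more compound is needed for the effect, a lower number that less compound is needed), compound 1 gives 145 nM, compound 2 gives 126 nM and compound 3 gives 49 nM, the lowest number of the three. For the measured compounds named here, the step of a 1.2-fold lower number from compound 1 to compound 2 (0.06 log units; within the scatter) stays within the scatter, whereas a 3.0-fold lower number from compound 1 to compound 3 (0.47 log units; beyond the scatter) and a 2.6-fold lower number from compound 2 to compound 3 (0.41 log units; beyond the scatter) go beyond it, so the 2-(methylcarbamoyl)ethyl chain is the only change so far that lowered the number.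

Compound 4 `O=C(CCc1ccc(NCc2cccc(Oc3ccccc3)c2)cc1)N1CCCC1` keeps that chain and alters only the amide end: pyrrolidin-1-yl in place of methylamino on a carbonyl carbon. Going by the values given here, no measured step touches the amide nitrogen itself; the two modest steps into compound 3 compare an amide against two acids and say nothing about what sits on that nitrogen. The nearest guidance is therefore indirect, and a step in this assay of no settled direction, most likely within the scatter, is expected for a 1.2-fold higher number from compound 3 to compound 4 (0.09 log units; within the scatter). Compound 4 is estimated at 60 nM, with a range from 20 nM to 180 nM, pending the measurement.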

Compound 4, half-maximal effective concentration: 115 nM
The estimate for compound 4 lay 1.9-fold (0.28 log units) below the measured number; measured number inside the range.
By their numbers in this assay, from the lowest: compound 3; then compounds 4, 2 and 1 (each within the scatter of the next).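

The amide nitrogen is not a silent position: in this assay the change to pyrrolidin-1-yl on the carbonyl carbon gives a 2.3-fold higher number from compound 3 to compound 4 (0.37 log units; beyond the scatter) and is a modest step, though it swaps a group with 1 hydrogen-bond donor for a five-membered ring with none, so the loss of the donor and the gain of the ring cannot be told apart. The amide link alone therefore does not set compound 3 apart from the acids, since the 2-((pyrrolidin-1-yl)carbonyl)ethyl chain gives a 1.1-fold lower number from compound 2 to compound 4 (0.04 log units; within the scatter) and a 1.3-fold lower number from compound 1 to compound 4 (0.10 log units; within the scatter) and both steps stay within the scatter. No measurement offered here accounts for the step at the amide nitrogen.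

Open, from the compounds shown here alone, is which feature of methylamino matters: a plain amino group, dimethylamino or ethylamino on the same carbonyl carbon would separate the amide hydrogen from the size of the group, and piperidin-1-yl would extend the ring comparison. Also open, going by these compounds, is whether the methylamino result holds on a longer chain between the aromatic carbon and the carbonyl.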